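This account rests on a few compounds, and the source may have more. Where it says the series, first, only, none or still open, it means among the compounds named here.

Compound 1 `C[C@H](CCO)CC[C@@H]1[C@@]2(C)CCCC(C)(C)[C@@H]2CC[C@@]1(C)O` stands in a functional assay on RAW264.7 cells (Mus musculus) for inhibition, read by ELISA, with stated times of 30 min and 24 h (a higher number here means a weaker inhibitor, a lower number a stronger inhibitor), at 25000 nM, level with compound 2 `CC(=O)OCC[C@@H](C)CC[C@@H]1[C@@]2(C)CCCC(C)(C)[C@@H]2CC[C@@]1(C)O`, which gives 25000 nM, so that the step of no change at the digits printed from compound 1 to compound 2 (within the scatter) lies within the scatter. Compound 3 `C[C@H](CCOC(=O)c1ccc(Br)cc1)CC[C@@H]1[C@@]2(C)CCCC(C)(C)[C@@H]2CC[C@@]1(C)O` reaches only a limit of this assay, > 50000 nM, and so sits at the limit of > 50000 nM in this assay, at which 1 of the 3 values shown sits. The steps of an at least 2.0-fold higher number from compound 1 to compound 3 (0.30 log units; that floor lies within the scatter) and an at least 2.0-fold higher number from compound 2 to compound 3 (0.30 log units; that floor lies within the scatter) therefore have floors that also lie within the scatter.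

Compound 4 `C[C@H](CC=O)CC[C@@H]1[C@@]2(C)CCCC(C)(C)[C@@H]2CC[C@@]1(C)O` differs from compound 1 by formyl in place of hydroxymethyl on a saturated chain carbon, four bonds along the chain from a saturated ring carbon. Within the data shown here, no measured step changes the same group: the three measured steps alter the hydrogen on the oxygen of compound 1 to an acetyl or a (4-bromophenyl)carbonyl, and the larger of them ends at a limit. From them one can only take that changes at this end of the chain left the number unchanged or moved it by a step whose floor is within the scatter. The account therefore expects no step beyond the scatter from compound 1 to compound 4, no change at the digits printed from compound 1 to compound 4 (within the scatter). In this assay compound 4 is estimated at 25000 nM, with a range from 10000 nM to 60000 nM.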

Compound 4, half-maximal inhibitory concentration: > 50000 nM
Compound 4 ended at the assay's limit; the forecaster's own chance of this, stated with the estimate: 30%; middle value at least 2.0-fold (0.30 log units) away from the limit.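

In this assay, putting formyl in place of hydroxymethyl gives an at least 2.0-fold higher number from compound 1 to compound 4 (0.30 log units; that floor lies within the scatter), and putting it in place of acetoxymethyl gives an at least 2.0-fold higher number from compound 2 to compound 4 (0.30 log units; that floor lies within the scatter). The earlier steps shown here altered only what sits on the oxygen, while this one changes the hydroxymethyl itself, and the number again ends at a limit, as it did for compound 3 with its (4-bromophenyl)carbonyl. Both new steps are floors within the scatter, so they show no change beyond it, and this end of the chain now has two compounds at the same limit: the limit of > 50000 nM in this assay, at which 2 of the 4 values shown sit.

On these data alone, how far compound 3 and compound 4 lie past that limit stays unknown, so no order can be read between them. As far as these compounds go, whether an amine, a carboxylic acid or a longer chain at this end would give a number inside the assay's range also remains open.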